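Swapping the Aryl Group on a Weak Cell Inhibitor

The compounds below may be only part of what the source reports. "The series", "measured", "known", "first", "only" and "open" are said of these compounds alone.

Compound 1 `Nc1cccc(-c2cn3nc(Cc4ccccc4)sc3n2)c1` gives 37000 nM in a functional assay on CCRF-CEM cells (Homo sapiens) for inhibition, read by cell counting, with a stated time of 3 days; a higher number here means a weaker inhibitor, a lower number a stronger inhibitor. Going by the values given here, compound 2 `Nc1cccc(-c2cn3nc(Cc4ccc(Cl)cc4)sc3n2)c1` gives 42000 nM in this assay, the highest of the two numbers so far, although the step of a 1.1-fold higher number from compound 1 to compound 2 (0.06 log units; within the scatter) is within the scatter. Compound 3 `COc1cccc(Cc2nn3cc(-c4cccc(N)c4)nc3s2)c1` carries 3-methoxyphenyl in place of 4-chlorophenyl on a saturated chain carbon bound to an aromatic carbon. Among the compounds with values here, the only measured step that bears on this change, a 1.1-fold higher number from compound 1 to compound 2 (0.06 log units; within the scatter), also altered the group on that saturated chain carbon and barely moved the number, so nothing beyond the scatter is expected. Compound 3 is therefore estimated at 40000 nM, between 15000 nM and 100000 nM. The expected step of a 1.1-fold lower number from compound 2 to compound 3 (0.02 log units; within the scatter) stays within the scatter.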

Compound 3, half-maximal inhibitory concentration: 40000 nM
Estimate against measurement, compound 3: no gap at the digits printed; the range from low to high includes it.
By their numbers in this assay, from the lowest: compounds 1, 3 and 2 (each within the scatter of the next).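

Swapping 4-chlorophenyl for 3-methoxyphenyl on a saturated chain carbon bound to an aromatic carbon introduces an oxygen and a hydrogen-bond acceptor, yet this assay records a 1.1-fold lower number from compound 2 to compound 3 (0.02 log units; within the scatter) as the outcome. Adding methoxy to the plain phenyl ring gives a 1.1-fold higher number from compound 1 to compound 3 (0.03 log units; within the scatter) as well, so this position has now taken two different substituents with no step beyond the scatter. No evidence is available to explain this flat result. Still open, going by these compounds, is whether a carboxylic acid or an amine on this ring would shift the number beyond the scatter. A longer chain in place of the saturated chain carbon is equally untested by these compounds.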